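The compounds below may be only part of what the source reports. "The series", "measured", "known", "first", "only" and "open" are said of these compounds alone.

Measured compounds in the series:

Compound 1 `C=CCn1c(=O)/c(=C\c2cc(F)ccc2C)[nH]c(=O)/c1=C\c1ccccc1OC` gives 5600 nM in a functional assay on Huh-7 cells (Homo sapiens) for cytotoxicity, read by CCK-8 assay, with a stated time of 72 h; on this read-out higher numbers stand for weaker inhibition and lower numbers for stronger inhibition.
Compound 2 `COc1ccccc1/C=c1\c(=O)[nH]/c(=C/c2ccccc2Cl)c(=O)n1C` gives 300 nM in this assay.
Compound 3 `C=CCn1c(=O)/c(=C\c2ccc(F)c(Br)c2)[nH]c(=O)/c1=C\c1ccccc1OC` is recorded as "not active" (no number reported) in this assay, with no number reported.

Compound 3 thus stands at the bottom of what has been measured: it carries no single value, only the statement that no half-maximal inhibitory concentration could be read, while compound 1 and compound 2 both return numbers, compound 2 the lower of the two. Going by the values given here, no step between compounds that differ in a single place is available, so the effect of swapping one aryl group for another cannot be sized from the data themselves.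

Compound 4 `C=CCn1c(=O)/c(=C\c2cccc(Cl)c2)[nH]c(=O)/c1=C\c1ccccc1OC` differs from compound 3 by 3-chlorophenyl in place of 3-bromo-4-fluorophenyl on a double-bonded chain carbon bound to an aromatic carbon. Going from an inactive compound, the step in this assay can only run toward a measurable number or stay at no number; with nothing to anchor its size, a modest gain that brings compound 4 into the measurable range is the most that is expected, and a repeat of the inactive result remains quite possible. Compound 4 is expected at about 9000 nM, with a range from 2000 nM to 40000 nM.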

Compound 4, half-maximal inhibitory concentration: 8900 nM
For compound 4 the middle estimate is 1.0-fold (0.00 log units) above the measured one, within the range that was stated.
By their numbers in this assay, from the lowest: compound 2; then compounds 1 and 4 (each within the scatter of the next).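

In this assay compound 3, carrying 3-bromo-4-fluorophenyl, is recorded as "not active" (no number reported) while compound 4, carrying 3-chlorophenyl on the same double-bonded chain carbon bound to an aromatic carbon, gives 8900 nM and so shows that the identity of this aryl group decides whether a number can be read at all, though the size of that step cannot be read. Exchanging 5-fluoro-2-methylphenyl for 3-chlorophenyl gives a 1.6-fold higher number from compound 1 to compound 4 (0.20 log units; within the scatter) so those two groups are not told apart in this assay and a readable number at this position is not tied to one substitution on the phenyl ring. No measurement shown here bears on the reason for either result.

Compound 2 differs from the other compounds in more than one place, so its 300 nM cannot be assigned to any single group. Also open, on these data alone, is how a phenyl ring bearing an amine or a carboxylic acid would read at this position, and whether the separation between the inactive compound 3 and the measurable compound 4 would hold for such groups.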